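Shifting the Hydroxyl Around One Aryl Ring

The source may hold more compounds than are shown below. What is called first, only, known or untested is meant among the compounds shown, and "the series" means these compounds.

Compound 1 `Oc1ccc(-c2cc(-c3ccco3)cc(-c3ccccc3O)n2)cc1` — > 50000 nM in a functional assay on HeLa cells (Homo sapiens) for cytotoxicity, read by CCK-8 assay (on this read-out higher numbers stand for weaker inhibition and lower numbers for stronger inhibition), a limit of the assay
Compound 2 `Oc1ccc(-c2cc(-c3ccco3)cc(-c3cccc(O)c3)n2)cc1` — 5170 nM in this assay

Within the data shown here, compound 2 carries the only number in this assay; the other reading is a limit (the limit of > 50000 nM in this assay, at which 1 of the 2 values shown sits). Among the measured compounds shown here, the single measured step, an at least 9.6-fold lower number from compound 1 to compound 2 (0.98 log units; beyond the scatter), moved the hydroxyl from 2-hydroxyphenyl to 3-hydroxyphenyl. Compound 3 `Oc1ccc(-c2cc(-c3ccco3)cc(-c3ccc(O)cc3)n2)cc1` differs from compound 2 by 4-hydroxyphenyl in place of 3-hydroxyphenyl on an aromatic carbon. That step gives weak guidance here, so no change beyond the scatter is expected, a 1.2-fold higher number from compound 2 to compound 3 (0.06 log units; within the scatter). Compound 3 is estimated at 6000 nM, with a range from 1500 nM to 30000 nM.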

Compound 3, half-maximal inhibitory concentration: > 50000 nM
Compound 3 ended at the assay's limit; the forecaster's own chance of this, stated with the estimate: 20%; middle value at least 8.3-fold (0.92 log units) away from the limit.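

Moving the hydroxyl on to 4-hydroxyphenyl gave an at least 9.6-fold higher number from compound 2 to compound 3 (0.98 log units; beyond the scatter), so the change at this position does not run in one direction: among the three compounds, only the 3-hydroxyphenyl group of compound 2 gives a measured number. Compound 1 and compound 3 each end at a limit of the assay: the limit of > 50000 nM in this assay, at which 2 of the 3 values shown sit. The step between those two cannot be read, so they cannot be ranked against each other. On these data alone, it remains open whether a methoxy group or an amine at the 3-position of this phenyl ring would keep the number of compound 2. An unsubstituted phenyl group would show whether the hydroxyl is needed at all.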